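The compounds below may be only part of what the source reports. "The series", "measured", "known", "first", "only" and "open" are said of these compounds alone.

Measured compounds:
- compound 1 `Nc1nc(N/N=C/c2cncs2)nc2c1ncn2[C@@H]1O[C@H](CO)[C@@H](O)[C@H]1O`: 22 nM
- compound 2 `Nc1nc(N/N=C/c2cccnc2Cl)nc2c1ncn2[C@@H]1O[C@H](CO)[C@@H](O)[C@H]1O`: 4.6 nM
- compound 3 `N#Cc1ccccc1/C=N/Nc1nc(N)c2ncn([C@@H]3O[C@H](CO)[C@@H](O)[C@H]3O)c2n1`: 2.9 nM

In an assay on CHO-K1 cells for displacement of a labelled ligand from adenosine receptor A1 (Homo sapiens), read by scintillation counting, with a stated time of 60 min (on this read-out lower numbers stand for stronger inhibition and higher numbers for weaker inhibition), compound 1 stands at the highest of the three numbers, with compound 2 giving 4.6 nM and compound 3 giving 2.9 nM. The two changes made at the carbon with a double bond to nitrogen both moved the read-out beyond the scatter: a 4.8-fold lower number from compound 1 to compound 2 (0.68 log units; beyond the scatter) and a 7.6-fold lower number from compound 1 to compound 3 (0.88 log units; beyond the scatter). Between those two products the gap is small, a 1.6-fold lower number from compound 2 to compound 3 (0.20 log units; within the scatter).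

The unmeasured compound 4 `CN(C)c1ccc(/C=N/Nc2nc(N)c3ncn([C@@H]4O[C@H](CO)[C@@H](O)[C@H]4O)c3n2)cc1` differs from compound 1 in the same place: 4-(dimethylamino)phenyl in place of 1,3-thiazol-5-yl on a carbon with a double bond to nitrogen. Like compounds 2 and 3, it carries a six-membered aromatic ring where compound 1 carries a five-membered one, so the steps from compound 1 to compounds 2 and 3 are the ones that bear on it. On that basis a modest lowering of the number, beyond the scatter, is expected: a 3.7-fold lower number from compound 1 to compound 4 (0.56 log units; beyond the scatter). Compound 4 is estimated at 6 nM in this assay, within a range from 2 nM to 25 nM.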

Compound 4, inhibition constant: > 10000 nM
Compound 4: no number, only a limit; the forecaster's own chance of this, stated with the estimate: 2%; at least 1600-fold (3.22 log units) between middle value and limit.
By their numbers in this assay, from the lowest: compounds 3 and 2 (each within the scatter of the next); then compound 1. At a limit, above all of these: compound 4.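

In this assay compound 4 gives no number, only a limit: the limit of > 10000 nM in this assay, at which 1 of the 4 values shown sits. This shows that the carbon with a double bond to nitrogen does not take every six-membered aromatic ring with a low number, as compound 2 and compound 3 alone might have suggested. The change to 4-(dimethylamino)phenyl gives an at least 450-fold higher number from compound 1 to compound 4 (2.65 log units; beyond the scatter), and the steps from the two six-membered cases are larger still, with an at least 2100-fold higher number from compound 2 to compound 4 (3.33 log units; beyond the scatter) and an at least 3400-fold higher number from compound 3 to compound 4 (3.53 log units; beyond the scatter).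

The compounds shown leave open whether the loss follows the dimethylamino group or the carbon-only phenyl ring that carries it. An unsubstituted phenyl ring, or a phenyl ring bearing a methoxy group or a primary amine in place of the dimethylamino group, would begin to separate these two readings.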